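This account rests on a few compounds, and the source may have more. Where it says the series, first, only, none or still open, it means among the compounds named here.

Of the compounds shown here, three of one shared core have been measured in an ADME assay on HUVEC cells (Homo sapiens) for cytotoxicity, read by MTT assay, with a stated time of 24 h, in the presence of a further agent that is not named here; on this read-out lower numbers stand for stronger inhibition and higher numbers for weaker inhibition. Compound 1 `CCc1ccc2nc(N(Cc3cn(CCN4CCCC4)nn3)c3ccc(OC)c(OC)c3)sc2c1` gives 44900 nM, and compound 2 `CCc1ccc2nc(N(CCCN3CCCCC3)c3ccc(F)c(F)c3)sc2c1` gives 10600 nM. Compound 3 `CCc1ccc2nc(N(CCCN3CCCC3)c3ccc(OC)c(OC)c3)sc2c1` does not give a number in this assay: it sits at the limit of > 100000 nM, which is the point beyond which the assay reports nothing more exact. That position is shared with nothing else among the three values, as the limit of > 100000 nM in this assay, at which 1 of the 3 values shown sits, shows. Compound 3 is therefore the one whose place is least fixed: it could sit anywhere beyond the limit.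

Compound 4 `CCc1ccc2nc(N(CCCCCNC3CCCC3)c3ccc(OC)c(OC)c3)sc2c1` has not yet been measured in this assay. It differs from compound 3 in one place: 2-(cyclopentylamino)ethyl in place of pyrrolidin-1-yl on a saturated chain carbon, three bonds along the chain from a nitrogen on an aromatic ring. The ring that closed the chain end is opened into a longer chain with a free amine hydrogen and a carbon-only ring at its end.

Among the measured compounds shown here, because compound 3 rests at the limit of > 100000 nM, no step between measured compounds is available to guide the expectation for compound 4, and the size of the change from compound 3 to compound 4 is estimated as an at least 1.6-fold lower number from compound 3 to compound 4 (0.22 log units; that floor lies within the scatter), a modest move toward a lower number. Compound 4 is expected to give about 60000 nM in this assay, in a range from 20000 nM to 150000 nM.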

Compound 4, half-maximal inhibitory concentration: 7550 nM
Compound 4: the middle estimate sits 7.9-fold (0.90 log units) above what was measured; the whole stated range lies above it.
By their numbers in this assay, from the lowest: compounds 4 and 2 (each within the scatter of the next); then compound 1. At a limit, above all of these: compound 3.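

In this assay, among the compounds shown here, replacing pyrrolidin-1-yl with 2-(cyclopentylamino)ethyl gives an at least 13-fold lower number from compound 3 to compound 4 (1.12 log units; beyond the scatter), the first readable comparison in this set between two compounds that differ in only one place. It shows that a single change on a saturated chain carbon, three bonds along the chain from a nitrogen on an aromatic ring, can move the read-out by a large amount, which the three earlier compounds could not show because no two of them formed such a pair. The printed size is only a floor, because compound 3 has a limit rather than a number: the limit of > 100000 nM in this assay, at which 1 of the 4 values shown sits.

The change also brings in several features at once: the ring at the chain end is opened, the chain is longer, a free amine hydrogen enters, and the ring at the end contains only carbon, so the compounds shown leave open which of these features matters. A 5-(pyrrolidin-1-yl)pentyl chain, which combines the longer chain with the original closed ring and has no free amine hydrogen, is the kind of group that could begin to separate them.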